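Swapping Fluoro for Acetyl: Expected Cytotoxicity of Compound 4

The compounds below may be only part of what the source reports. "The series", "measured", "known", "first", "only" and "open" are said of these compounds alone.

Three analogues of one shared core have been examined. Compound 1 `Cc1nc(C(NC(=O)C(=O)Nc2ccc(F)cc2)C2CCCCN2)sc1CCO` was tested in an ADME assay on MT2 cells (Homo sapiens) for cytotoxicity, read by XTT assay, with a stated time of 4 days (on this read-out lower numbers stand for higher toxicity in this test and higher numbers for lower toxicity in this test), where compound 1 gives 109000 nM, the highest of the two numbers shown. Compound 2 `Cc1nc(C(NC(=O)C(=O)Nc2ccc(Cl)cc2)C2CCCCN2C)sc1CCO` gives 88000 nM in this assay, which lies within the scatter of compound 1. Compound 3 `Cc1nc(C(NC(=O)C(=O)Nc2ccc(C(F)(F)F)cc2)C2CCCCN2)sc1CO` reaches only a limit of the assay in this assay, > 75500 nM, and not a number. Compound 4 `CC(=O)c1ccc(NC(=O)C(=O)NC(c2nc(C)c(CCO)s2)C2CCCCN2)cc1` has not yet been measured in this assay. It differs from compound 1 in one place: acetyl in place of fluoro on an aromatic carbon. Among the measured compounds shown here, no measured pair shows the effect of such a change, and the values so far sit close together, so no step beyond the scatter is expected in either direction. Compound 4 is therefore estimated at 100000 nM, between 50000 nM and 200000 nM. The expected step is a 1.1-fold lower number from compound 1 to compound 4 (0.04 log units; within the scatter).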

Compound 4, half-maximal cytotoxic concentration: > 48300 nM
Compound 4: only a limit was reported; the forecaster's own chance of this, stated with the estimate: 30%; the middle value lies beyond the limit too.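

Compound 4 gives > 48300 nM, which is a limit of the assay and not a number. The step from compound 1 to compound 4 cannot be read. The compounds shown leave open what acetyl in place of fluoro on an aromatic carbon does in this assay.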